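Swapping an aryl group on a triazole-linked cinnamic acid

The source may hold more compounds than are shown below. What is called first, only, known or untested is meant among the compounds shown, and "the series" means these compounds.

Four close relatives share one core. Compound 1 `COc1cccc(-n2cc(COc3c(/C=C\C(=O)O)ccc(OC)c3CC=C(C)C)nn2)c1` has no reported result in a functional assay on COLO 205 cells (Homo sapiens) for cytotoxicity, read by MTT assay, with a stated time of 24 h (a lower number here means a stronger inhibitor, a higher number a weaker inhibitor), its entry reading "not determined" (no result reported), and compound 3 `COc1ccc(/C=C\C(=O)O)c(OCc2cn(-c3cccnc3Cl)nn2)c1CC=C(C)C` likewise has no reported result, its entry reading "not determined" (no result reported). For the measured compounds named here, compound 2 `COc1ccc(/C=C\C(=O)O)c(OCc2cn(-c3cccc(C#N)c3)nn2)c1CC=C(C)C`, the only one with a number, gives 26800 nM in this assay, a weak effect. Going by the values given here, compound 3 therefore stands without a value of its own, and no measured step reaches it. Compound 4 `COc1ccc(/C=C\C(=O)O)c(OCc2cn(-c3cccc([N+](=O)[O-])c3)nn2)c1CC=C(C)C` differs from compound 3 by 3-nitrophenyl in place of 2-chloropyridin-3-yl on an aromatic nitrogen. Among the compounds with values here, with no step between measured compounds available, the expectation is that compound 4 stays near the weak level seen for compound 2, with no shift beyond the usual scatter. Compound 4 is thus estimated at 25000 nM in this assay, within a range from 8000 nM to 80000 nM.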

Compound 4, half-maximal inhibitory concentration: 6900 nM
Compound 4: the middle estimate sits 3.6-fold (0.56 log units) above what was measured, and the stated range ends above it.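

For the compounds shown here, this is the first measured step: in this assay, nitro in place of cyano on the aromatic carbon gives a 3.9-fold lower number from compound 2 to compound 4 (0.59 log units; beyond the scatter), a modest change. It shows that a single group on this aryl ring can shift the reading beyond the usual scatter. No supporting evidence is available to explain this difference. Going by these compounds, whether an amine or a carboxylic acid in place of the nitro group would lower the number further stays open, as does how far any change at this position could carry the series.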